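A few compounds are considered here, and "the series" means these few. Any claim that something is new, unique, unknown or untested is made for them only; others in the source may bear on it.

Compound 1 `CC(C)c1ccc(-c2nc(SCc3cn(CC(=O)NC(=O)Nc4ccccn4)nn3)nc(Nc3ccccc3Cl)c2C#N)cc1` gives in a functional assay on ECa-109 cells (Homo sapiens) for inhibition, read by MTT assay, with a stated time of 72 h (on this read-out higher numbers stand for weaker inhibition and lower numbers for stronger inhibition), a value of 23400 nM.
Compound 2 `CC(C)c1ccc(-c2nc(SCc3cn(CC(=O)NC(=O)Nc4ccccn4)nn3)nc(Nc3ccc(Cl)cc3)c2C#N)cc1` gives in this assay a value of 11200 nM.
Compound 3 `CC(C)c1ccc(-c2nc(SCc3cn(CC(=O)NC(=O)Nc4ccccn4)nn3)nc(Nc3ccccc3F)c2C#N)cc1` gives in this assay a value of 15500 nM.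

Compound 1 has the highest of the three numbers, with compound 3 nearest and compound 2 furthest. Compound 4 `CC(C)c1ccc(-c2nc(SCc3cn(CC(=O)NC(=O)Nc4ccccn4)nn3)nc(Nc3ccccc3)c2C#N)cc1` differs from compound 1 by hydrogen in place of chloro on an aromatic carbon. Among the compounds with values here, no measured step removes the chloro outright; the closest are a 1.5-fold lower number from compound 1 to compound 3 (0.18 log units; within the scatter), where one halogen replaces another, and a 2.1-fold lower number from compound 1 to compound 2 (0.32 log units; beyond the scatter), where the chloro moves. Both change the number only a little. Losing the chloro is therefore expected to give a small step in this assay, if anything toward a lower number, as a 1.5-fold lower number from compound 1 to compound 4 (0.17 log units; within the scatter). For compound 4 the estimate is 16000 nM, within 7000 nM to 36000 nM.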

Compound 4, half-maximal inhibitory concentration: > 64000 nM
Compound 4: only a limit was reported; the forecaster's own chance of this, stated with the estimate: 5%; middle value at least 4.0-fold (0.60 log units) away from the limit.
By their numbers in this assay, from the lowest: compounds 2, 3 and 1 (each within the scatter of the next, the first and the last beyond it). At a limit, above all of these: compound 4.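

The value for compound 4 is a limit of the assay, not a number: the limit of > 64000 nM in this assay, at which 1 of the 4 values shown sits. Each halogen-bearing compound therefore lies clearly below the unsubstituted phenyl compound, with an at least 2.7-fold higher number from compound 1 to compound 4 (0.43 log units; beyond the scatter), an at least 4.1-fold higher number from compound 3 to compound 4 (0.61 log units; beyond the scatter) and an at least 5.7-fold higher number from compound 2 to compound 4 (0.75 log units; beyond the scatter). Exchanging or moving the halogen had shifted the number only modestly at most, whereas having no halogen on this ring costs more, by an amount the limit leaves unknown.

As far as these compounds go, whether a halogen specifically is needed remains open. A methyl or methoxy group on this ring could show whether a non-halogen substituent serves as well.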